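A few compounds are considered here, and "the series" means these few. Any claim that something is new, unique, unknown or untested is made for them only; others in the source may bear on it.

Measured compounds:
- compound 1 `CCC(c1ccc(-c2cscc2C)cc1)n1ccnc1`: 584 nM
- compound 2 `CCC(c1ccc(-c2ccsc2)cc1)n1ccnc1`: 373 nM

In an assay for inhibition of steroid 17-alpha-hydroxylase/17,20 lyase (Homo sapiens), using NADPH (on this read-out lower numbers stand for stronger inhibition and higher numbers for weaker inhibition), compound 2 gives 373 nM, the lowest of the two numbers measured, while compound 1 gives 584 nM. The two lie within the scatter of each other: a 1.6-fold lower number from compound 1 to compound 2 (0.19 log units; within the scatter).

Compound 3 `CCC(c1ccc(-c2ccsc2Cl)cc1)n1ccnc1` is not yet measured. It differs from compound 2 by chloro in place of hydrogen on an aromatic carbon. Among the measured compounds shown here, the only measured step that bears on it is the one between compound 1 and compound 2, which also swaps a hydrogen and a small group on the same five-membered aromatic ring, and that step stayed within the scatter (a 1.6-fold lower number from compound 1 to compound 2 (0.19 log units; within the scatter)). With a single such step of that size to go on, no change beyond the scatter is expected in this assay for compound 3 in either direction; the expected step is a 1.1-fold higher number from compound 2 to compound 3 (0.03 log units; within the scatter). Compound 3 is therefore estimated at 400 nM in this assay, with a range of 150 nM to 1100 nM.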

Compound 3, half-maximal inhibitory concentration: 263 nM
Compound 3: the middle estimate sits 1.5-fold (0.18 log units) above what was measured; the range from low to high includes it.
By their numbers in this assay, from the lowest: compounds 3, 2 and 1 (each within the scatter of the next, the first and the last beyond it).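

With chloro on the carbon next to the ring sulfur and next to the ring atom that bears a large group, this assay shows a 1.4-fold lower number from compound 2 to compound 3 (0.15 log units; within the scatter), so this position accepts a chlorine atom without a change that can be told from the scatter. Read against the methyl-bearing ring, the exchange gives a 2.2-fold lower number from compound 1 to compound 3 (0.35 log units; beyond the scatter), a modest step and the only one among these three compounds that lies beyond the scatter, although the steps from compound 1 to compound 2 and from compound 2 to compound 3 each stay within it. Nothing measured here accounts for this difference.

The compounds shown leave open how this position responds to other groups, such as bromo, methoxy or an amine. They also leave open whether a carboxylic acid on this ring would produce a larger step.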